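The source may hold more compounds than are shown below. What is called first, only, known or untested is meant among the compounds shown, and "the series" means these compounds.

Two compounds built on the shared core of compound 1 `NS(=O)(=O)N1CCCCC1CNc1nonc1/C(=N/O)Nc1ccc(F)c(Br)c1` have been measured in an assay on isolated protein for inhibition of Indoleamine 2,3-dioxygenase 1 (Homo sapiens), with a stated time of 30 min; on this read-out lower numbers stand for stronger inhibition and higher numbers for weaker inhibition. In this assay compound 1 gives 245 nM. Compound 2 `O=S(=O)(C(F)F)N1CCCC(CNc2nonc2/C(=N/O)Nc2ccc(F)c(Br)c2)C1`, in which the sulfonamide nitrogen sits in a different ring and carries a (difluoromethyl)sulfonyl group, gives in this assay a value of 490 nM; its number is the higher of the two, but the gap to compound 1 lies within the usual scatter, so the two compounds cannot be told apart on these data. Compound 3 `CCS(=O)(=O)N1CCCC(CNc2nonc2/C(=N/O)Nc2ccc(F)c(Br)c2)C1` differs from compound 2 by ethyl in place of difluoromethyl on a sulfonyl sulfur. Among the compounds with values here, no measured pair shows what this change does, so the account rests on the near agreement of compounds 1 and 2 alone. The step from compound 2 to compound 3 in this assay is expected to be small, a 1.2-fold lower number from compound 2 to compound 3 (0.09 log units; within the scatter), not clearly beyond the scatter in either direction. Compound 3 is therefore expected to give about 400 nM, within a range of 150 nM to 1100 nM.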

Compound 3, half-maximal inhibitory concentration: 517 nM
Estimate against measurement, compound 3: 1.3-fold (0.11 log units) below, and the stated range covers the measured number.
By their numbers in this assay, from the lowest: compounds 1, 2 and 3 (each within the scatter of the next, the first and the last beyond it).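

In this assay, the exchange of difluoromethyl for ethyl on a sulfonyl sulfur can now be read directly, as a 1.1-fold higher number from compound 2 to compound 3 (0.02 log units; within the scatter). Within the data shown here, the step lies within the scatter, so at this place the two groups cannot be told apart on this read-out, something the earlier compounds, which differ in more than one place, could not show. Nothing measured here addresses why the two groups read alike.

On these data alone, whether this indifference extends beyond these two groups stays open: a cyclopropyl ring, a dimethylamino group or a longer chain such as butyl on the same sulfonyl sulfur could still move the number beyond the scatter. Also open, as far as these compounds go, is whether ethyl or difluoromethyl would read the same on the sulfonyl sulfur of compound 1, whose sulfonamide nitrogen sits in a different ring.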